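The source may report more compounds than this note shows. Statements on the series, on what has been measured and on what is new or still open speak of the compounds shown alone.

Measured so far:
compound 1, `Nc1cc(N)c2nc(-c3ccccc3)c(Oc3ccc(Cl)c(Cl)c3)nc2c1`, 5620 nM
compound 2, `COc1cc(CNc2nc3cc(N)cc(N)c3nc2-c2ccccc2)cc(OC)c1OC`, 16200 nM

Of the compounds shown here, two have been tested in a functional assay on SK-MEL-2 cells (Homo sapiens) for inhibition, read by sulforhodamine B assay, with a stated time of 48 h; a higher number here means a weaker inhibitor of growth, a lower number a stronger inhibitor of growth. Compound 1 gives 5620 nM, and compound 2, `COc1cc(CNc2nc3cc(N)cc(N)c3nc2-c2ccccc2)cc(OC)c1OC`, gives 16200 nM. Of the two numbers, that of compound 1 is the lower, and the gap to compound 2 lies beyond the scatter, so compound 1 is the stronger growth inhibitor of the pair. The two compounds differ in more than one place, so their gap cannot be tied to a single change.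

The next compound, compound 3, `Nc1cc(N)c2nc(-c3ccccc3)c(Oc3ccc(F)cc3)nc2c1`, keeps the core of compound 1 and alters only the group on the oxygen: 4-fluorophenyl in place of 3,4-dichlorophenyl on an oxygen on an aromatic ring. Among the compounds with values here, no pair of measured compounds shows the effect of this exchange, so the size of the step is open. The numbers at hand give no reason to expect a large change in this assay; a shift of modest size, in either direction and possibly within the scatter, seems the likeliest outcome.

The step from compound 1 to compound 3 is therefore expected to be a 1.6-fold higher number from compound 1 to compound 3 (0.20 log units; within the scatter). Compound 3 is estimated at 9000 nM, with a range from 3000 nM to 30000 nM.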

Compound 3, concentration for 50% growth inhibition: 42700 nM
For compound 3 the middle estimate is 4.7-fold (0.68 log units) below the measured one; the measured number lies above the stated range.
By their numbers in this assay, from the lowest: compound 1; then compound 2; then compound 3.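

In this assay, the exchange of 3,4-dichlorophenyl for 4-fluorophenyl on an oxygen on an aromatic ring gives a 7.6-fold higher number from compound 1 to compound 3 (0.88 log units; beyond the scatter), and this is the only comparison shown in which a single place changes. With the rest of compound 1 held fixed, the group on this oxygen is enough on its own to move the number beyond the scatter, so it is not a silent part of the structure, and the 3,4-dichlorophenyl form is the stronger growth inhibitor of this pair. Nothing at hand bears on what lies behind this step.

The two groups differ in more than one feature, since 3,4-dichlorophenyl carries two chlorine atoms and 4-fluorophenyl carries one fluorine atom, so the compounds shown do not say which part of the exchange accounts for the step. As far as these compounds go, how the number would respond to a 4-chlorophenyl, a 3-chlorophenyl or an unsubstituted phenyl on the same oxygen remains open, and so does the effect of a methoxy or trifluoromethyl group on that ring.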